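A few compounds are considered here, and "the series" means these few. Any claim that something is new, unique, unknown or untested is made for them only; others in the source may bear on it.

Measured so far:
compound 1 `COc1ccc(-c2cnn3c(NCc4ccccn4)cc(C)nc23)cc1` — < 5000 nM
compound 2 `Cc1cc(NCc2ccccn2)n2ncc(-c3ccncc3)c2n1` — 161000 nM

In a physicochemical assay for solubility, read by HPLC, using the shake flask method, measured as kinetic solubility, with a stated time of 2 h, at pH 7.4 (on this read-out higher numbers stand for higher solubility and lower numbers for lower solubility), compound 2 gives 161000 nM. For the measured compounds named here, this is the only finite number in the set. For compound 1 this assay reports only a limit, < 5000 nM. Going by the values given here, the one measured step, an at least 32-fold higher number from compound 1 to compound 2 (1.50 log units; beyond the scatter), is large, and its true size is open-ended due to the limit of < 5000 nM in this assay, at which 1 of the 2 values shown sits. Compound 2 therefore stands as the sole firm anchor for the series.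

Compound 3 `Cc1cc(NCc2ccccn2)n2ncc(-c3ccc(O)cc3)c2n1` differs from compound 2 by 4-hydroxyphenyl in place of pyridin-4-yl on an aromatic carbon. Among the compounds with values here, no measured step covers this exact exchange. Within the data shown here, the single measured step shows that swapping the group on this aromatic carbon can move this assay by a large amount, so a step beyond the scatter is expected rather than none. With compound 1 sitting at a limit, the direction and size for compound 3 rest on a single comparison and remain uncertain.

Compound 3 is expected to give 30000 nM in this assay, with a range from 5000 nM to 150000 nM. The expected step is a 5.4-fold lower number from compound 2 to compound 3 (0.73 log units; beyond the scatter), an estimated decrease from compound 2.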

Compound 3, solubility: 10900 nM
Compound 3: middle estimate off by 2.8-fold (0.44 log units), on the high side; the range from low to high includes it.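

Notes on this aromatic carbon: a 15-fold lower number from compound 2 to compound 3 (1.17 log units; beyond the scatter) in this assay shows that replacing 4-methoxyphenyl with another group does not by itself reproduce the number seen with pyridin-4-yl, so compound 2 remains highest of the three, with its steps to compound 1 and compound 3 both printed as beyond the scatter. For the compounds shown here, the exchange of pyridin-4-yl for 4-hydroxyphenyl also replaces a ring nitrogen with an all-carbon aromatic ring and adds a hydrogen-bond donor, but these changes occur together, so the single step cannot separate them. Going by these compounds alone, the smaller change of hydrogen in place of methyl on the oxygen gives an at least 2.1-fold higher number from compound 1 to compound 3 (0.33 log units; beyond the scatter), a first reading on the phenyl substituent alone, whose full size stays open due to the value of compound 1, which is a limit: the limit of < 5000 nM in this assay, at which 1 of the 3 values shown sits.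

The compounds shown leave open whether the high number of compound 2 depends on the pyridine nitrogen and its place in the ring, which pyridin-3-yl or pyridin-2-yl on the same carbon would test. They also leave open how an aminophenyl or carboxyphenyl group would compare with 4-hydroxyphenyl at this carbon.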